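Notes on the ring-nitrogen acid chain of compound 1

A few compounds are considered here, and "the series" means these few. Any claim that something is new, unique, unknown or untested is made for them only; others in the source may bear on it.

Compound 1 `CC(CC(=O)O)N1Cc2ccc(NC(=O)CC3CCNCC3)cc2C1=O` is the reference point of this small set. In a functional assay on a cell-free system (Platelet, plasma, Homo sapiens) for inhibition (a higher number here means a weaker inhibitor, a lower number a stronger inhibitor), compound 1 gives 2700 nM, the lowest of the three numbers. Compound 2 `CC(CC(=O)O)N1Cc2ccc(NC(=O)CCCC3CCNCC3)cc2C1=O` gives 5400 nM, and the step of a 2.0-fold higher number from compound 1 to compound 2 (0.30 log units; within the scatter) stays within the scatter, so no order between these two can be claimed. For the measured compounds named here, compound 3 `CC(CC(=O)O)N1Cc2ccc(NC(=O)c3cccc(N4CCNCC4)c3)cc2C1=O` gives 62000 nM, a gap to compound 1 that lies beyond the scatter; the two structures differ in more than one place, so no single step is read from them.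

Compound 4 `O=C(O)CN1Cc2ccc(NC(=O)CC3CCNCC3)cc2C1=O` differs from compound 1 on the other side of the shared core: carboxymethyl in place of 1-(carboxymethyl)ethyl on an amide-type nitrogen in a ring. Going by the values given here, no measured step touches this position; the one step available, between compound 1 and compound 2, concerns the chain on the amide and was within the scatter. The data therefore give no direction for this change, and the expectation is a step that stays within the scatter or close to it, with the wider uncertainty an untested position carries. Compound 4 is estimated at 4000 nM, with a range from 1500 nM to 12000 nM. That estimate corresponds to an expected 1.5-fold higher number from compound 1 to compound 4 (0.17 log units; within the scatter).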

Compound 4, half-maximal inhibitory concentration: 51000 nM
Compound 4: the middle estimate sits 13-fold (1.11 log units) below what was measured; the measured number lies above the stated range.
By their numbers in this assay, from the lowest: compounds 1 and 2 (each within the scatter of the next); then compounds 4 and 3 (each within the scatter of the next).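

Notes on the result at the ring nitrogen: in this assay the change of carboxymethyl in place of 1-(carboxymethyl)ethyl reads as a 19-fold higher number from compound 1 to compound 4 (1.28 log units; beyond the scatter) and lies beyond the scatter, so this position is not silent, whereas the one earlier step, on the amide chain, stayed within it. Counted on the two groups, the change is 6 heavy atoms against 4, with no ring in either and the same counts of donors and acceptors. Nothing at hand bears on why a change of this size gives so large a step.

Open, on these data alone, is whether a longer chain on the ring nitrogen, such as 3-carboxypropyl, or an ethyl branch in place of the methyl branch, would keep the number of compound 1. Also open, as far as these compounds go, is whether the same step would hold with the amide chain of compound 2.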